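Removing the amide side chain: expected effect on cytotoxicity

A few compounds are considered here, and "the series" means these few. Any claim that something is new, unique, unknown or untested is made for them only; others in the source may bear on it.

Compound 1 `COc1cc2cc(C(=O)Nc3ccccc3)c(=O)oc2cc1OCCCOc1no[n+]([O-])c1S(=O)(=O)c1ccccc1`: 9670 nM
Compound 2 `COc1cc2cc(C(=O)NCCCc3ccccc3)c(=O)oc2cc1OCCCOc1no[n+]([O-])c1S(=O)(=O)c1ccccc1`: 5330 nM

In an ADME assay on MCF-10A cells (Homo sapiens) for cytotoxicity, read by MTT assay, with a stated time of 48 h (on this read-out lower numbers stand for stronger inhibition and higher numbers for weaker inhibition), compound 2 gives 5330 nM. Within the data shown here, its only neighbour is compound 1, and the step of a 1.8-fold lower number from compound 1 to compound 2 (0.26 log units; within the scatter) lies within the scatter, so the two compounds cannot be told apart on these numbers. Compound 3 `COc1cc2cc(N)c(=O)oc2cc1OCCCOc1no[n+]([O-])c1S(=O)(=O)c1ccccc1` differs from compound 2 by amino in place of (3-phenylpropyl)carbamoyl on an aromatic carbon. Among the measured compounds shown here, the one measured step, a 1.8-fold lower number from compound 1 to compound 2 (0.26 log units; within the scatter), changes only the group on the amide nitrogen and keeps the amide; it does not test removal of the whole carbamoyl group. For the measured compounds named here, no measured step bears directly on this change. The expected step of a 1.5-fold higher number from compound 2 to compound 3 (0.18 log units; within the scatter) is therefore small, within the scatter. Compound 3 is estimated at 8000 nM, with a range from 2500 nM to 30000 nM.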

Compound 3, half-maximal inhibitory concentration: 6450 nM
For compound 3 the middle estimate is 1.2-fold (0.09 log units) above the measured one; low and high end bracket the measured number.
By their numbers in this assay, from the lowest: compounds 2, 3 and 1 (each within the scatter of the next).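

In this assay the amide side chain can be removed entirely at this aromatic carbon: amino in place of (3-phenylpropyl)carbamoyl gives a 1.2-fold higher number from compound 2 to compound 3 (0.08 log units; within the scatter) and amino in place of phenylcarbamoyl gives a 1.5-fold lower number from compound 1 to compound 3 (0.18 log units; within the scatter) on the same carbon. The earlier compounds shown here all kept the amide, so only now is it clear that losing it, along with its aromatic ring, leaves no readable change in this read-out. Nothing available here explains this result. Still open, on these data alone, is whether a different group on this carbon, such as a carboxylic acid or a methyl ester, would move the number beyond the scatter.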